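Swapping methoxy for cyano on a piperidine-phenyl core

The source may report more compounds than this note shows. Statements on the series, on what has been measured and on what is new or still open speak of the compounds shown alone.

Measured compounds:
- compound 1, `O=C(NCN1CCC(c2cccc[n+]2[O-])CC1)c1ccccc1`: 63%
- compound 2, `COc1ccccc1C1CCN(CC(=O)Nc2cccc(C)c2)CC1`: 43%
- compound 3, `c1ccc(C2CCN(Cc3nc4ccccc4[nH]3)CC2)nc1`: 62%

All three were tested in a functional assay on HEK293 cells for agonist activity at D(4) dopamine receptor (Homo sapiens), read by FLIPR; a higher number here means a larger maximal response, a lower number a smaller maximal response. Compound 2 stands lowest of the three numbers. Its nearest neighbour is compound 3, whose value lies higher by an amount beyond the usual scatter, and compound 1 lies higher still, also beyond the scatter. Compound 2 is thus the weakest of the measured set in this assay.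

The next compound, compound 4, `Cc1cccc(NC(=O)CN2CCC(c3ccccc3C#N)CC2)c1`, keeps the whole of compound 2 except one group. The change is cyano in place of methoxy on an aromatic carbon. Cut one bond further out, it reads 2-methoxyphenyl to 2-cyanophenyl.

Within the data shown here, no measured pair in this set differs in only this one place, so there is no directly comparable step to lean on. Both groups leave and enter with the same count of heavy atoms and the same count of hydrogen-bond acceptors, and neither carries a charge. On that basis a step no larger than the scatter is expected, with no clear direction, so a number 4 percentage points higher from compound 2 to compound 4 (within the scatter) is the estimated move. Compound 4 is therefore expected to give about 47%, within a range from 30% to 68%.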

Compound 4, largest response reached (reported as efficacy), in percent of the reference or control that the assay uses: 71%
The estimate for compound 4 lay 24 percentage points below the measured number; measured number outside the range, above it.
By their numbers in this assay, from the lowest: compound 2; then compounds 3, 1 and 4 (each within the scatter of the next).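

In this assay, among these compounds, the change from methoxy to cyano gives a number 28 percentage points higher from compound 2 to compound 4 (beyond the scatter) and is the only comparison here that isolates a single place, since the rest of the molecule stays the same. This place, on an aromatic carbon ortho to a large group, therefore matters for the maximal response: the two groups match in heavy atoms and hydrogen-bond acceptors and neither carries a charge, yet the step lies beyond the scatter, so these counts alone do not predict the outcome here. Nothing measured on these compounds accounts for the rise, so its origin remains unexplained.

With a single step at this place, it remains unclear whether the higher response is specific to cyano or would also appear with another replacement for methoxy, such as a chlorine atom, a fluorine atom, a methyl group or a plain hydrogen. As far as these compounds go, it is also open whether the same swap would produce a similar rise on a different scaffold, such as the core of compound 3, whose other parts differ from those of compound 4 in more than one place.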